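From Phenyl to Methoxyphenoxy: an Expected Acid Dissociation Constant

The compounds below may be only part of what the source reports. "The series", "measured", "known", "first", "only" and "open" are said of these compounds alone.

Three compounds have been measured in a physicochemical assay for acid dissociation:
Compound 1 `Fc1ccc(-c2ccc3c(NCCCNCc4ccco4)ccnc3c2)cc1` gives 9.47.
Compound 2 `COc1cccc(Oc2ccc3c(NCCCNCc4ccco4)ccnc3c2)c1` gives 9.28.
Compound 3 `c1ccc(-c2ccc3c(NCCCNCc4ccco4)ccnc3c2)cc1` gives 9.47.

Compound 3 stands level with compound 1, the step of no change at the digits printed from compound 1 to compound 3 (within the scatter) being no change at all. Among the measured compounds shown here, the only other number, that of compound 2, differs from it by a number 0.19 log units higher from compound 2 to compound 3 (within the scatter), a gap that lies within the scatter of this kind of measurement.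

Compound 4 `COc1ccc(Oc2ccc3c(NCCCNCc4ccco4)ccnc3c2)cc1` differs from compound 3 in one place: 4-methoxyphenoxy in place of phenyl on an aromatic carbon. For the measured compounds named here, two measured steps bear on this. The step of a number 0.19 log units higher from compound 2 to compound 3 (within the scatter) swapped a methoxyphenoxy group for phenyl at the same place and stayed within the scatter, and the step of a number 0.19 log units lower from compound 1 to compound 2 (within the scatter) likewise stayed within the scatter. Nothing recorded here shows a change at this part of the molecule moving the read-out, higher or lower, beyond the scatter.

Compound 4 is therefore expected to give about 9.35 in this assay, within a range of 9.05 to 9.65. The expected step of a number 0.12 log units lower from compound 3 to compound 4 (within the scatter) is estimated to be small, not beyond the scatter.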

Compound 4, acid dissociation constant: 9.28
Beside the measured number, compound 4's estimate is 0.07 log units above it, and the stated range covers the measured number.
By their numbers in this assay, from the lowest: compounds 2, 4, 1 and 3 (each within the scatter of the next).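

In this assay, 4-methoxyphenoxy on this aromatic carbon, with 9 heavy atoms in place of the 6 of phenyl, gives a number 0.19 log units lower from compound 3 to compound 4 (within the scatter), and the swap for 4-fluorophenyl gives a number 0.19 log units lower from compound 1 to compound 4 (within the scatter), so both replacements stay inside the scatter. The new compound also tests the methoxy group's place on the outer ring: 4-methoxyphenyl in place of 3-methoxyphenyl on the oxygen gives no change at the digits printed from compound 2 to compound 4 (within the scatter), so that change leaves the read-out unmoved at the digits printed. Nothing available here explains why these steps are so small.

All four compounds carry a six-membered aromatic ring of carbon at this place, directly or through an oxygen. Going by these compounds, whether a different kind of group there, such as an amine or a carboxylic acid, would move the read-out beyond the scatter remains open.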